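Chloro to Methyl: Expectation for Compound 3

The source may hold more compounds than are shown below. What is called first, only, known or untested is meant among the compounds shown, and "the series" means these compounds.

Compound 2 `COc1cc(-c2cc(-c3ccc(Cl)cc3)nc(-c3ccccc3)n2)cc(OC)c1OC` is known in a functional assay on MDA-MB-231 cells (Homo sapiens) for inhibition, read by MTT assay, with a stated time of 48 h (on this read-out lower numbers stand for stronger inhibition and higher numbers for weaker inhibition), only as a limit: compound 2 gives > 25000 nM. Its parent, compound 1 `COc1cc(-c2cc(-c3ccc(O)cc3O)nc(-c3ccccc3)n2)cc(OC)c1OC`, gives 810 nM in this assay. Going by the values given here, the one measured step, an at least 30-fold higher number from compound 1 to compound 2 (1.48 log units; beyond the scatter), is thus a large loss of inhibition, and compound 2 sits at the limit of > 25000 nM in this assay, at which 1 of the 2 values shown sits. Compound 3 `COc1cc(-c2cc(-c3ccc(C)cc3)nc(-c3ccccc3)n2)cc(OC)c1OC` differs from compound 2 by methyl in place of chloro on an aromatic carbon. Among the compounds with values here, no measured step exchanges a chloro for a methyl; the single recorded step concerns a different exchange and gives no direct guide to the size of this one. As compound 2 is known only as a limit, the change from compound 2 to compound 3 can be set only loosely, and one expects none beyond the scatter, a step that the limit leaves unreadable from compound 2 to compound 3. Compound 3 is accordingly estimated at 30000 nM, within 8000 nM to 100000 nM, with a good chance that only a limit is reported again.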

Compound 3, half-maximal inhibitory concentration: 5110 nM
Compound 3: middle estimate off by 5.9-fold (0.77 log units), on the high side, outside the stated range (below it).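

In this assay, the exchange at this position is not silent: the record shows an at least 4.8-fold lower number from compound 2 to compound 3 (0.68 log units; beyond the scatter), so chloro and methyl are not interchangeable here, and a phenyl ring without hydroxyl groups can still give a measurable value. The recovery is only partial, with a 6.3-fold higher number from compound 1 to compound 3 (0.80 log units; beyond the scatter), so the 4-methylphenyl group does not make up for the loss of the 2,4-dihydroxyphenyl group. Compound 2 is known only as a limit, so the step from the chloro compound has a floor and no ceiling: the limit of > 25000 nM in this assay, at which 1 of the 3 values shown sits.

Going by these compounds, it remains open how an amine, a methoxy group or an ethyl chain in place of the methyl of compound 3 would read in this assay. Also open, on these data alone, is whether one hydroxyl group alone would suffice, or whether compound 1 needs both.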